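The source may report more compounds than this note shows. Statements on the series, on what has been measured and on what is new or still open speak of the compounds shown alone.

Measured so far:

Compound 1, `CC1(C)S[C@@H]2C/C(=C\C(=O)c3ccccc3)C(=O)N2[C@H]1C(=O)OC(c1ccccc1)c1ccccc1`, in a functional assay on OE19 cells (Homo sapiens) for cytotoxicity, read by MTT assay, with a stated time of 48 h (on this read-out higher numbers stand for weaker inhibition and lower numbers for stronger inhibition), gives 73300 nM.
Compound 2, `CC1(C)S[C@@H]2/C(=C\C(=O)c3ccc([N+](=O)[O-])cc3)C(=O)N2[C@H]1C(=O)OC(c1ccccc1)c1ccccc1`, gives 44100 nM.

Compound 2 has the lower of the two numbers, but compound 1 sits close enough that the gap falls within the usual scatter of repeated measurements, so the two cannot be told apart on these data. Compound 3, `CC1(C)S[C@@H]2/C(=C\C(=O)c3ccc(F)cc3)C(=O)N2[C@H]1C(=O)OC(c1ccccc1)c1ccccc1`, has not yet been measured. It differs from compound 2 in one place: fluoro in place of nitro on an aromatic carbon. For the measured compounds named here, no step between measured compounds covers a change of this kind, so there is nothing measured to lean on. With only the two numbers in hand, the expected step is a 1.2-fold higher number from compound 2 to compound 3 (0.10 log units; within the scatter), small and not beyond the scatter in either direction, with at most a slight lean toward a higher number. The value expected for compound 3 is 55000 nM, with a range from 20000 nM to 150000 nM.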

Compound 3, half-maximal inhibitory concentration: 12100 nM
For compound 3 the middle estimate is 4.5-fold (0.66 log units) above the measured one, and the stated range ends above it.
By their numbers in this assay, from the lowest: compound 3; then compounds 2 and 1 (each within the scatter of the next).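

In this assay, replacing 4-nitrophenyl with 4-fluorophenyl gives a 3.6-fold lower number from compound 2 to compound 3 (0.56 log units; beyond the scatter), so what sits on this aromatic carbon clearly matters. For the compounds shown here, the two earlier compounds differ in more than one place and could not show this, making this the first reading of a single change in the set. Here, one fluorine atom in place of the three heavy atoms of the nitro group goes with stronger inhibition, but nothing measured here bears on the reason for the step.

A single step between two groups does not establish a trend: a chloro group, a methoxy group or an amine at the same place could fall on either side of these numbers. From the compounds shown here alone, it also remains open whether the same swap would have a similar effect on a different core, such as that of compound 1.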